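Series notes: meta-substituted benzamides on the shared core

A few compounds are considered here, and "the series" means these few. Any claim that something is new, unique, unknown or untested is made for them only; others in the source may bear on it.

Among the compounds with values here, compound 2 `Cc1cccc(C(=O)Nc2c(C(O)(C(F)(F)F)C(F)(F)F)ccc3ccccc23)c1` stands lowest of the two numbers so far in a functional assay (Sus scrofa) with sulfonylurea receptors; K-ATP channels (Homo sapiens) as the target (on this read-out higher numbers stand for an effect only at larger amounts of compound and lower numbers for an effect already at smaller amounts), with 52.5 nM; compound 1 `COCC(=O)Nc1c(C(O)(C(F)(F)F)C(F)(F)F)ccc2ccccc12` gives 204 nM, and the only measured step, a 3.9-fold lower number from compound 1 to compound 2 (0.59 log units; beyond the scatter), follows from 3-methylphenyl in place of methoxymethyl on a carbonyl carbon. Compound 3 `O=C(Nc1c(C(O)(C(F)(F)F)C(F)(F)F)ccc2ccccc12)c1cccc([N+](=O)[O-])c1` is not yet measured. Its difference from compound 2, (nitro in place of methyl on an aromatic carbon), sits at the same position on the 3-phenyl ring, so the core and amide are kept. Within the data shown here, no measured step replaces one ring substituent with another; the step from compound 1 to compound 2 changes the whole group on the carbonyl carbon and does not bear directly on this exchange. The expectation is therefore a step in this assay of uncertain direction, most likely not beyond the scatter, written as a 1.1-fold higher number from compound 2 to compound 3 (0.06 log units; within the scatter). The estimate for compound 3 in this assay is 60 nM, with a range from 20 nM to 200 nM.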

Compound 3, half-maximal effective concentration: 427 nM
Beside the measured number, compound 3's estimate is 7.1-fold (0.85 log units) below it, and the stated range ends below it.
By their numbers in this assay, from the lowest: compound 2; then compound 1; then compound 3.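

In this assay this ring position proves sensitive: with the shared core and amide kept, nitro in place of methyl gives an 8.1-fold higher number from compound 2 to compound 3 (0.91 log units; beyond the scatter) on an aromatic carbon meta to a large group. Set against methoxymethyl on the carbonyl carbon, the 3-nitrophenyl group gives a 2.1-fold higher number from compound 1 to compound 3 (0.32 log units; beyond the scatter) in the opposite direction to the 3-methylphenyl group, so among these compounds an aryl group there does not in itself bring a lower number, and compound 3 goes against any such reading. Nothing available on these compounds accounts for the size of this change.

The compounds shown leave open where other groups at this place would fall, such as an amine, a chlorine atom or a methoxy group. Also open, going by these compounds, is whether the unsubstituted phenyl ring sits nearer to the 3-methylphenyl or the 3-nitrophenyl compound.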